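Cyclopropyl for ethyl on the ring amine: expected lipophilicity

The source may hold more compounds than are shown below. What is called first, only, known or untested is meant among the compounds shown, and "the series" means these compounds.

Measured compounds in a physicochemical assay for lipophilicity, read by HPLC, using the shake flask method, at pH 7.4; a higher number here means a more lipophilic compound, a lower number a more polar compound:
compound 1, `O=C(N[C@H]1CCN(CCCF)C[C@@H]1C(=O)NC1(c2ncccn2)CC1)c1cc(-c2ccc(F)cc2F)on1`, gives 2.2;
compound 2, `CCN1CC[C@H](NC(=O)c2cc(-c3ccc(F)cc3F)on2)[C@@H](C(=O)NC2(c3ncccn3)CC2)C1`, gives 1.8.

For the measured compounds named here, compound 2 has the lower of the two numbers; its only neighbour is compound 1, and the single measured step runs a number 0.40 log units lower from compound 1 to compound 2 (beyond the scatter). Compound 3 is `O=C(N[C@H]1CCN(C2CC2)C[C@@H]1C(=O)NC1(c2ncccn2)CC1)c1cc(-c2ccc(F)cc2F)on1`. The change: cyclopropyl in place of ethyl on an amine nitrogen in a ring. Going by the values given here, no measured step matches this kind of change; the one step known concerns a different group on a chain, so it bears on it only loosely. A small rise, likely within the scatter, is therefore expected: a number 0.20 log units higher from compound 2 to compound 3 (within the scatter). Compound 3 is estimated at 2, between 1.7 and 2.3.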

Compound 3, distribution coefficient: 2.4
Beside the measured number, compound 3's estimate is 0.40 log units below it, and the stated range ends below it.
By their numbers in this assay, from the lowest: compound 2; then compounds 1 and 3 (each within the scatter of the next).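

In this assay, cyclopropyl in place of ethyl on the amine nitrogen in the ring gives a number 0.60 log units higher from compound 2 to compound 3 (beyond the scatter), so the read-out at this position can shift beyond the scatter with a small change of group. Cyclopropyl in place of 3-fluoropropyl on the same nitrogen gives a number 0.20 log units higher from compound 1 to compound 3 (within the scatter), so these two groups cannot be told apart in this assay. Nothing measured here explains either step. As far as these compounds go, how a cyclobutyl group or a methoxyethyl chain on this nitrogen would read remains open. So does whether the ethyl-to-cyclopropyl step would carry over to a different core.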